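The compounds below may be only part of what the source reports. "The series", "measured", "known", "first", "only" and "open" are said of these compounds alone.

In a functional assay on HCT-116 cells (Homo sapiens) for antiproliferative activity, read by MTT assay, with a stated time of 72 h (a lower number here means a stronger inhibitor, a higher number a weaker inhibitor), compound 1 `O=C(CCc1cccc2c1B(O)OC2)Nc1ccc(I)cc1` gives 50000 nM, while compound 2 `O=C(CCc1cccc2c1B(O)OC2)Nc1cccc(I)c1` gives 2300 nM. Compound 2 therefore holds the lower of the two numbers and is the stronger inhibitor of this pair. Compound 3 `O=C(CCc1cccc2c1B(O)OC2)Nc1cccc(-c2cccc(Cl)c2)c1` keeps the shared core and amide chain of compound 2 but exchanges the iodine for a whole new aromatic ring: 3-chlorophenyl in place of iodo on an aromatic carbon. In words, a 3-chlorophenyl stands in place of iodo on an aromatic carbon, meta to a large group.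

Among the measured compounds shown here, only one measured step bears on this change, and it bears only indirectly. That large step, a 22-fold lower number from compound 1 to compound 2 (1.34 log units; beyond the scatter), came from 3-iodophenyl taking the place of 4-iodophenyl on an amide-type nitrogen. For the measured compounds named here, it shows that the arrangement on this ring can matter a great deal in this assay, but no measured step replaces iodo with another group. The direction is therefore uncertain, and only a modest lean towards a lower number, within the scatter, is expected: a 1.5-fold lower number from compound 2 to compound 3 (0.19 log units; within the scatter). For compound 3 the estimated value is 1500 nM, with an expected range from 300 nM to 8000 nM.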

Compound 3, half-maximal inhibitory concentration: 350 nM
For compound 3 the middle estimate is 4.3-fold (0.63 log units) above the measured one, and the stated range covers the measured number.
By their numbers in this assay, from the lowest: compound 3; then compound 2; then compound 1.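

In this assay, the place on the ring held by iodo accepts a much larger group, and the exchange for 3-chlorophenyl gives a 6.6-fold lower number from compound 2 to compound 3 (0.82 log units; beyond the scatter) in a step that lies beyond the scatter. Among the compounds shown here, the earlier pair only moved iodine around the ring, whereas this is the first measured change that replaces the iodo group itself, showing that one heavy atom can give way to 7 heavy atoms, including a whole six-membered aromatic ring, with no loss of activity in this cell assay. No measurement here offers an explanation for the lower number, so the result stands as an observation without an established cause.

On these data alone, it remains open how much of this step belongs to the new aromatic ring and how much to its chlorine, a question that a plain phenyl group at the same place could help to answer. As far as these compounds go, it is also open whether a different kind of group at this place, such as an amine or a carboxylic acid, would give a number nearer to that of compound 3 or further from it.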